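Cyano to Carbamoyl in a Series at Its Limit

A few compounds are considered here, and "the series" means these few. Any claim that something is new, unique, unknown or untested is made for them only; others in the source may bear on it.

Of the compounds shown here, three have been measured so far, and none of them gives a number. In a functional assay on Raji cells (Homo sapiens) for cytotoxicity, with a stated time of 72 h (on this read-out higher numbers stand for an effect only at larger amounts of compound and lower numbers for an effect already at smaller amounts), compound 1 (`C=C[C@@](C)(/C=C/c1ccc(O)cc1)CC/C=C/C(=O)OCC`) gives > 26000 nM as a limit and not a number. Compound 2 (`C=C[C@@](C)(/C=C/c1ccc(O)cc1)CC/C=C(\C)C(=O)OCC`) gives > 26000 nM in this assay as a limit as well. Compound 3 (`C=C[C@@](C)(/C=C/c1ccc(O)c(/C=C/C#N)c1)CCC=C(C)C`) likewise gives > 26000 nM as a limit. Compound 3 thus stands at the limit of > 26000 nM in this assay, at which 3 of the 3 values shown sit, and cannot be placed in any order against compound 1 or compound 2.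

Compound 4 (`C=C[C@@](C)(/C=C/c1ccc(O)c(/C=C/C(N)=O)c1)CCC=C(C)C`) has not yet been measured. It departs from compound 3 in one place, with carbamoyl in place of cyano on a double-bonded chain carbon bound to a double-bonded chain carbon. The same difference, cut one bond further out, reads 2-cyanoethenyl to 2-carbamoylethenyl.

Among the compounds with values here, no measured pair shows a change of this kind, so the size of the step in this assay has to be judged from compound 3 alone. No shift beyond the scatter, in either direction, is expected because the limit of > 26000 nM in this assay, at which 3 of the 3 values shown sit, offers no sign of a measurable effect in this series. The expected change is a number no higher from compound 3 to compound 4 (the limit leaves the size open) and no more. For compound 4 the estimate is 26000 nM (expected range 13000 nM to 40000 nM) with a reported limit as the likeliest outcome.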

Compound 4, half-maximal effective concentration: > 26000 nM
Compound 4: only a limit was reported (the forecaster's own chance of this, stated with the estimate: 80%); the middle value lies on the limit itself.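

Within the data shown here, compound 3 and compound 4 both sit at a limit, so no step from cyano to carbamoyl can be read between them: the limit of > 26000 nM in this assay, at which 4 of the 4 values shown sit.

The compounds shown leave open whether any member of this series gives a number in this assay and whether carbamoyl and cyano would then differ at all.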